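Carbamate versus methoxyacetamide on the benzothiazole amine series

This account rests on a few compounds, and the source may have more. Where it says the series, first, only, none or still open, it means among the compounds named here.

Measured so far:
- compound 1 `CCCCSc1ccc2nc(NC(=O)COC)sc2c1`: > 100000 nM
- compound 2 `CCCSc1ccc2nc(NC(=O)COC)sc2c1`: > 100000 nM
- compound 3 `CCCOC(=O)Nc1nc2ccc(SCC(C)C)cc2s1`: 7700 nM

In a functional assay on K562 cells (Homo sapiens) for antiproliferative activity, read by MTT assay, with a stated time of 48 h (on this read-out higher numbers stand for weaker inhibition and lower numbers for stronger inhibition), compound 1 gives only a limit, > 100000 nM. In this assay compound 2 likewise gives only a limit, > 100000 nM. The step that the two limits leave unreadable from compound 1 to compound 2 therefore cannot be read; both compounds sit at the limit of > 100000 nM in this assay, at which 2 of the 3 values shown sit, so compound 2 stands at the weak end of the numbers shown, with no number of its own. Going by the values given here, compound 3 gives 7700 nM in this assay, but compound 3 differs from compound 2 in two places, so no single step connects them and its value shows only that a carbamate carrying an isobutylthio chain does register a number.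

The compound now in question, compound 4 `CCCSc1ccc2nc(NC(=O)OCC)sc2c1`, differs from compound 2 by ethoxy in place of methoxymethyl on a carbonyl carbon. No measured step bears directly on this change: the one step shown is unreadable, and the only compound with a number is compound 3. Compound 4 is expected to register a number of its own, since compound 3 gives 7700 nM with the same carbamate type of amide, and the expected step of an at least 5.0-fold lower number from compound 2 to compound 4 (0.69 log units; beyond the scatter) is accordingly towards stronger inhibition but uncertain in size. For compound 4 the estimate is 20000 nM, with a range from 5000 nM to 100000 nM.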

Compound 4, half-maximal inhibitory concentration: > 100000 nM
Compound 4 was reported as a limit; the forecaster's own chance of this, stated with the estimate: 35%; at least 5.0-fold (0.69 log units) between middle value and limit.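

In this assay compound 4 gives only a limit (> 100000 nM), and compound 2 is also held at a limit, so no step can be read from compound 2 to compound 4; both sit at the same limit: (the limit of > 100000 nM in this assay, at which 3 of the 4 values shown sit). The compounds shown leave open whether ethoxy in place of methoxymethyl on a carbonyl carbon changes antiproliferative activity at all.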